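This account rests on a few compounds, and the source may have more. Where it says the series, first, only, none or still open, it means among the compounds named here.

Measured compounds:
Compound 1, `Cc1ccc(C)c(-n2nncc2CN2C(=O)C3(C(C#N)=C(N)Oc4c(N)cc5nc6ccccc6nc5c43)c3ccccc32)c1`. In a functional assay on A549 cells (Homo sapiens) for antiproliferative activity, read by MTT assay, with a stated time of 48 h (on this read-out lower numbers stand for stronger inhibition and higher numbers for weaker inhibition), compound 1 gives > 50000 nM, which is a limit of the assay and not a number.
Compound 2, `N#CC1=C(N)Oc2c(N)cc3nc4ccccc4nc3c2C12C(=O)N(Cc1cnnn1-c1c(F)cccc1F)c1ccccc12`. In this assay compound 2 gives > 50000 nM, again a limit rather than a number.

Compound 2 therefore stands only at a limit in this assay, and so does compound 1. Going by the values given here, the one step between the measured compounds, a step that the two limits leave unreadable from compound 1 to compound 2, cannot be read in size or direction, since both of its ends sit at the limit of > 50000 nM in this assay, at which 2 of the 2 values shown sit.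

Compound 3, `Cc1cc(C)c(-n2nncc2CN2C(=O)C3(C(C#N)=C(N)Oc4c(N)cc5nc6ccccc6nc5c43)c3ccccc32)c(C)c1`, has not yet been measured. It differs from compound 2 in one place: 2,4,6-trimethylphenyl in place of 2,6-difluorophenyl on an aromatic nitrogen. Among the compounds with values here, the only measured step, from compound 1 to compound 2, also exchanged the group on that aromatic nitrogen and gave no readable size, so it offers no guide to the size or direction of the present change. The step of a number no higher from compound 2 to compound 3 (the limit leaves the size open) that the estimate below means is expected to stay within the scatter, with the result most probably reported again only as a limit. Compound 3 is thus expected to give about 50000 nM in this assay, within a range from 20000 nM to 100000 nM.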

Compound 3, half-maximal inhibitory concentration: 12700 nM
Estimate against measurement, compound 3: 3.9-fold (0.60 log units) above; the measured number lies below the stated range.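

Compound 1 and compound 2 left the group on this aromatic nitrogen without any readable effect in this assay, and the step between them cannot be read: the limit of > 50000 nM in this assay, at which 2 of the 3 values shown sit.

Compound 3 brings the first real number, so the group at this position can shift the read-out. Placing 2,4,6-trimethylphenyl there gives an at least 3.9-fold lower number from compound 2 to compound 3 (0.59 log units; beyond the scatter), and the same group gives an at least 3.9-fold lower number from compound 1 to compound 3 (0.59 log units; beyond the scatter), where only the smallest possible size of each step is known. Methyl groups on the ring are not enough on their own, as compound 1 carries 2,5-dimethylphenyl and still stays at a limit of the assay.

Going by these compounds alone, with only three compounds, it remains open which feature of the 2,4,6-trimethylphenyl group goes with the lower number, and whether the number can fall further. Also open, on these data alone, is how an unsubstituted phenyl ring, a phenyl ring carrying an amine or a saturated cyclohexyl ring would behave on this nitrogen.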